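Amine caps on the thiocarbonyl carbon: working notes

The source may report more compounds than this note shows. Statements on the series, on what has been measured and on what is new or still open speak of the compounds shown alone.

Measured so far:
compound 1 `CC1CCCCN1C(=S)SCc1ccc(C(=O)Nc2ccccc2N)cc1`: 45.5%
compound 2 `Nc1ccccc1NC(=O)c1ccc(CSC(=S)N2CCc3ccc([N+](=O)[O-])cc32)cc1`: 45.7%
compound 3 `Nc1ccccc1NC(=O)c1ccc(CSC(=S)N2CCN(c3ncccn3)CC2)cc1`: 52.2%

Three compounds have been run in a functional assay on HeLa cells (Homo sapiens) for antiproliferative activity, read by CCK-8 assay, with a stated time of 72 h, tested at 2 uM; a higher number here means a stronger effect of the compound at the concentration tested, a lower number a weaker effect. Compound 1 stands as the lowest of the three numbers, but compound 2 lies nearest to it, a gap within the scatter, and compound 3, the furthest, is also within the scatter of compound 1. Among the measured compounds shown here, with all three caps on the thiocarbonyl carbon giving values in the same band, the series so far shows no separation among them; no step between two measured compounds that differ in one place is available.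

The next compound, compound 4 `CN(C(=S)SCc1ccc(C(=O)Nc2ccccc2N)cc1)c1cccnc1`, differs from compound 1 in one place:

methyl(pyridin-3-yl)amino in place of 2-methylpiperidin-1-yl on a thiocarbonyl carbon

Given that three quite different caps on the thiocarbonyl carbon all land within the scatter of one another in this assay, the step from compound 1 to compound 4 is expected to be small, with no direction beyond the scatter, a number 1.5 percentage points higher from compound 1 to compound 4 (within the scatter). For compound 4 the estimate in this assay is 47%, with a range from 36% to 58%.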

Compound 4, a percentage reported as inhibition, at one concentration (the size of the read-out at that concentration, not a potency): 16%
Compound 4: middle estimate off by 31 percentage points, on the high side; the whole stated range lies above it.
By their numbers in this assay, from the lowest: compound 4; then compounds 1, 2 and 3 (each within the scatter of the next).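

In this assay, the cap on the thiocarbonyl carbon is not indifferent after all: methyl(pyridin-3-yl)amino in place of 2-methylpiperidin-1-yl gives a number 29.5 percentage points lower from compound 1 to compound 4 (beyond the scatter), the first separation beyond the scatter in the series. The shared band of compounds 1, 2 and 3 therefore does not extend to every cap, and this single change on the thiocarbonyl carbon is enough to lower the read-out substantially. Among the compounds shown here, nothing measured so far identifies what accounts for the loss.

The step replaces a non-aromatic ring attached through its own nitrogen with an aromatic ring carrying a hydrogen-bond acceptor and a separate methyl on the amine, so these features remain confounded. A methyl(phenyl)amino cap, without the pyridine nitrogen, and a dimethylamino cap, without any ring, would help separate them.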